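Working notes: amine swap on the shared core

The source may report more compounds than this note shows. Statements on the series, on what has been measured and on what is new or still open speak of the compounds shown alone.

Measured in a functional assay on ECa-109 cells for inhibition, with ECa-109 cell line (Homo sapiens) as the target, read by sulforhodamine B assay; on this read-out higher numbers stand for weaker inhibition and lower numbers for stronger inhibition
- compound 1 `O=C1C(Nc2ccccc2F)=CC(=O)c2c1nc1n2[C@H]2OC[C@@H](O)[C@H]2OC1` gives 2660 nM
- compound 2 `Cc1ccc(NC2=CC(=O)c3c(nc4n3[C@H]3OC[C@@H](O)[C@H]3OC4)C2=O)cc1C` gives 4090 nM
- compound 3 `O=C1C(N2CCC2)=CC(=O)c2c1nc1n2[C@H]2OC[C@@H](O)[C@H]2OC1` gives > 16000 nM

For compound 3 the reading > 16000 nM is a limit of the assay and not a number. Compound 4 `CCCN(CCC)C1=CC(=O)c2c(nc3n2[C@H]2OC[C@@H](O)[C@H]2OC3)C1=O` differs from it as follows: dipropylamino in place of azetidin-1-yl on a double-bonded ring carbon so dipropylamino stands in place of azetidin-1-yl on a double-bonded ring carbon. Among the compounds with values here, no measured step leads from azetidin-1-yl to a comparable group. The nearest evidence is an at least 6.0-fold higher number from compound 1 to compound 3 (0.77 log units; beyond the scatter) and an at least 3.9-fold higher number from compound 2 to compound 3 (0.59 log units; beyond the scatter) with both beyond the scatter, while a 1.5-fold higher number from compound 1 to compound 2 (0.19 log units; within the scatter) stays within it. Compound 4 is therefore expected to remain close to compound 3 in this assay with no step beyond the scatter, the expected step being an at least 1.1-fold lower number from compound 3 to compound 4 (0.05 log units; that floor lies within the scatter) at most in size. Compound 4 is estimated at 14000 nM with an expected range of 6000 nM to 30000 nM in this estimate.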

Compound 4, half-maximal inhibitory concentration: > 16000 nM
Compound 4 gave a limit, no number; the forecaster's own chance of this, stated with the estimate: 50%; middle value at least 1.1-fold (0.05 log units) away from the limit.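

The reading of compound 4, > 16000 nM, is a limit of the assay and not a number. An open-chain dipropylamino group in place of the arylamino groups gives an at least 3.9-fold higher number from compound 2 to compound 4 (0.59 log units; beyond the scatter) and an at least 6.0-fold higher number from compound 1 to compound 4 (0.77 log units; beyond the scatter), so the higher numbers seen with azetidin-1-yl are not confined to a four-membered ring on the double-bonded ring carbon. The step from compound 3 to compound 4 cannot be read: the limit of > 16000 nM in this assay, at which 2 of the 4 values shown sit.

Still open, on these data alone, is whether the aryl ring or the hydrogen on the amine nitrogen goes with the lower numbers of compound 1 and compound 2. A cyclohexylamino group on the same ring carbon would separate the two.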